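The source may hold more compounds than are shown below. What is called first, only, known or untested is meant among the compounds shown, and "the series" means these compounds.

Measured so far in an ADME assay on cells (Hepatocyte, Mus musculus) for metabolic stability, with a stated time of 30 min (a higher number here means that more of the compound is left, a lower number that less of the compound is left), are three compounds:

compound 1 `CS(=O)(=O)NC1CCC(CN2CCN(c3cc(=O)c4cc(C(F)(F)F)cc([N+](=O)[O-])c4s3)CC2)CC1` gives 111%
compound 2 `O=C(OC1CCC(CN2CCN(c3cc(=O)c4cc(C(F)(F)F)cc([N+](=O)[O-])c4s3)CC2)CC1)c1ccc(C(F)(F)F)cc1` gives 28.8%
compound 3 `O=c1cc(N2CCN(CC3CCCCC3)CC2)sc2c([N+](=O)[O-])cc(C(F)(F)F)cc12` gives 80.6%

Compound 3 stands second highest of the three numbers, with both gaps beyond the scatter. Compound 4 `O=C(OC1CCC(CN2CCN(c3cc(=O)c4cc(C(F)(F)F)cc([N+](=O)[O-])c4s3)CC2)CC1)c1ccc(F)cc1` has ((4-fluorophenyl)carbonyl)oxy in place of hydrogen on a saturated ring carbon, a change counted as ((4-fluorophenyl)carbonyl)oxy in place of hydrogen on a saturated ring carbon here. For the measured compounds named here, the only measured step at such a carbon, a number 30.4 percentage points lower from compound 1 to compound 3 (beyond the scatter) in size, concerns methanesulfonamido and so bears only loosely. Closer guidance comes from compound 2, which also carries a substituted phenyl carbonyloxy group and gives 28.8% in this assay. A large fall beyond the scatter is therefore expected, and the estimated step is a number 48.6 percentage points lower from compound 3 to compound 4 (beyond the scatter) in size. For compound 4 the expected value is 32%, with an estimated range from 15% to 55%.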

Compound 4, percent of the compound remaining: 1.5%
Estimate against measurement, compound 4: 30.5 percentage points above; the whole stated range lies above it.
By their numbers in this assay, from the lowest: compound 4; then compound 2; then compound 3; then compound 1.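

In this assay, ((4-fluorophenyl)carbonyl)oxy on the saturated ring carbon gives a number 79.1 percentage points lower from compound 3 to compound 4 (beyond the scatter) relative to hydrogen, and replacing methanesulfonamido there gives a number 109.5 percentage points lower from compound 1 to compound 4 (beyond the scatter) for the same group. The aromatic substituent of this group also matters, since fluoro in place of trifluoromethyl gives a number 27.3 percentage points lower from compound 2 to compound 4 (beyond the scatter) on top of the fall already seen with compound 2. No measurement at hand explains these steps. From the compounds shown here alone, whether a plain hydroxyl or an amide link at that ring carbon would give similarly low numbers stays open, as does the outcome with an unsubstituted phenyl.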